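One chlorine fewer on the 3,5-dichlorophenyl group

A few compounds are considered here, and "the series" means these few. Any claim that something is new, unique, unknown or untested is made for them only; others in the source may bear on it.

In a functional assay on LOX IMVI cells (Homo sapiens) for inhibition, read by sulforhodamine B assay, with a stated time of 48 h (on this read-out higher numbers stand for weaker inhibition of growth and lower numbers for stronger inhibition of growth), compound 1 `CN1CCN(CCCOc2cccc3nc(Nc4ccc(Cl)c(C(F)(F)F)c4)ccc23)CC1` gives 1560 nM and compound 2 `CN1CCN(CCCOc2cccc3nc(Nc4cc(Cl)cc(Cl)c4)ccc23)CC1` gives 1580 nM, so these two numbers lie within the scatter of each other. The next structure, compound 3 `CN1CCN(CCCOc2cccc3nc(Nc4cccc(Cl)c4)ccc23)CC1`, turns the 3,5-dichlorophenyl group of compound 2 into 3-chlorophenyl, with hydrogen in place of chloro on an aromatic carbon. Among the compounds with values here, only one measured step bears on this change: a 1.0-fold higher number from compound 1 to compound 2 (0.01 log units; within the scatter). That step exchanged one chlorinated phenyl group for another and stayed within the scatter, but it does not test the loss of a single chlorine on its own. The evidence is thin, so no shift beyond the scatter is expected in this assay, and no firm direction can be given. The estimated step is a 1.1-fold higher number from compound 2 to compound 3 (0.06 log units; within the scatter). For compound 3 the expected value is 1800 nM, with an estimated range from 900 nM to 4000 nM.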

Compound 3, concentration for 50% growth inhibition: 1680 nM
The estimate for compound 3 lay 1.1-fold (0.03 log units) above the measured number; low and high end bracket the measured number.
By their numbers in this assay, from the lowest: compounds 1, 2 and 3 (each within the scatter of the next).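

Within the data shown here, replacing one chloro of the 3,5-dichlorophenyl group with hydrogen tests the loss of a single chlorine on its own for the first time, and in this assay it gives a 1.1-fold higher number from compound 2 to compound 3 (0.03 log units; within the scatter). This aromatic carbon can therefore carry either chloro or hydrogen without a shift beyond the scatter. The comparison with the 4-chloro-3-(trifluoromethyl)phenyl group gives a 1.1-fold higher number from compound 1 to compound 3 (0.03 log units; within the scatter), so 3-chlorophenyl also cannot be told apart from that group, and no measurement available here offers an explanation for these small steps.

On these data alone, it remains open whether plain phenyl, with the last chloro also replaced by hydrogen, would stay within the scatter. The effect of a different kind of group on this carbon, such as a methoxy group, an amine or a carboxylic acid, is also unknown.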